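This account rests on a few compounds, and the source may have more. Where it says the series, first, only, none or still open, it means among the compounds named here.

Of the compounds shown here, three have been measured in an ADME assay on RAW264.7 cells (Mus musculus) for cytotoxicity, read by MTT assay, with a stated time of 24 h, tested at 5 ug/mL; on this read-out higher numbers stand for a weaker effect at the one concentration tested and lower numbers for a stronger effect. Compound 1 `COc1cc(/C=C/C(=O)c2cccc(O)c2)ccc1O` gives 63.8%. Compound 3 `COc1ccc(/C=C/C(=O)c2ccc(OC)c(OC)c2)cc1` gives 78.9%. Compound 2 `COc1ccc(CCC(=O)c2cccc(O)c2)cc1` gives 94.5%, the highest of the three numbers: compound 3 stands nearest to it, lower by a gap beyond the scatter, and compound 1 stands furthest, lower by a wider gap. Compound 4 `COc1ccc(CCC(=O)c2cccc(O)c2)c(OC)c1` has not yet been measured in this assay. It differs from compound 2 in one place: methoxy in place of hydrogen on an aromatic carbon. Among the compounds with values here, no two measured compounds differ in a single place, so the size of such a step cannot be read from the data. The expected step is a number 6.5 percentage points lower from compound 2 to compound 4 (within the scatter), small and possibly not beyond the scatter. Compound 4 is therefore estimated at 88%, within a range from 72% to 100%.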

Compound 4, a percentage reported as activity, at one concentration (the size of the read-out at that concentration, not a potency): 88.8%
The estimate for compound 4 lay 0.8 percentage points below the measured number; low and high end bracket the measured number.
By their numbers in this assay, from the lowest: compound 1; then compounds 3, 4 and 2 (each within the scatter of the next, the first and the last beyond it).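

In this assay, within the data shown here, this is the first step that can be read from a single change: methoxy in place of hydrogen, ortho to a large group, gives a number 5.7 percentage points lower from compound 2 to compound 4 (within the scatter) and so lies within the scatter. At this position on the core of compound 2, the added methoxy therefore gives no read-out that can be told apart from hydrogen. Nothing measured here offers an explanation for this result. As far as these compounds go, whether an amine or a carboxylic acid at this position would give a step beyond the scatter remains open. So does whether methoxy on other carbons of this ring would behave the same way.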